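Replacing the Anilino Link with an Aryl Ether

A few compounds are considered here, and "the series" means these few. Any claim that something is new, unique, unknown or untested is made for them only; others in the source may bear on it.

This account follows one change in a small set of compounds sharing one core. Compound 1 `Cc1c(Nc2ccc(C#N)cc2Cl)ncnc1OC1C2COCC1CN(S(=O)(=O)C1CC1)C2` and compound 2 `Cc1c(Nc2ccc(C#N)cc2Cl)ncnc1OC1C2COCC1CN(C(=O)OC(C)(C)C)C2` were each measured more than once in a functional assay on HEK293 cells for agonist activity at Glucose-dependent insulinotropic receptor (Homo sapiens), read by fluorescence and cAMP accumulation, with a stated time of 30 min; a higher number here means that more compound is needed for the effect, a lower number that less compound is needed: compound 1 gives 51 nM; 1210 nM (2 entries), and compound 2 gives 7 nM; 20 nM (2 entries). Compound 3 `Cc1c(Nc2ccc(C#N)cc2Cl)ncnc1OC1C2COCC1CN(C(=O)OC1(C)CC1)C2` gives 4 nM in this assay, the only number shown for it, with two further entries that did not yield a single number.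

Compound 4 `Cc1c(Oc2ccc(C#N)cc2Cl)ncnc1OC1C2COCC1CN(C(=O)OC1(C)CC1)C2` differs from compound 3 in one place: 2-chloro-4-cyanophenoxy in place of (2-chloro-4-cyanophenyl)amino on an aromatic carbon. The entering group carries 0 hydrogen-bond donors where the leaving group carried 1, while both carry 2 hydrogen-bond acceptors. Among the compounds with values here, no pair of measured compounds in this set shares this change, so the size of the step has no precedent here.

For this assay the account expects compound 4 to need somewhat more compound than compound 3, a step of a 3.5-fold higher number from compound 3 to compound 4 (0.54 log units; beyond the scatter) that is expected to lie beyond the usual scatter but not by a wide margin. Compound 4 is therefore estimated at 14 nM, with a likely range from 3 nM to 70 nM.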

Compound 4, half-maximal effective concentration: 16 nM
For compound 4 the middle estimate is 1.1-fold (0.06 log units) below the measured one; the measured number falls inside the stated range.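

Within the data shown here, the step, a 4.0-fold higher number from compound 3 to compound 4 (0.60 log units; beyond the scatter), in this assay, gives the first measured size for placing 2-chloro-4-cyanophenoxy instead of (2-chloro-4-cyanophenyl)amino on this aromatic carbon, something the earlier compounds, which all carry the amino link, could not show. The entering group has no hydrogen-bond donor, yet compound 4 still gives 16 nM, so in this set the hydrogen-bond donor of the amino link is not needed for a measurable effect in this assay, although the exchange does carry a modest cost. The size of that cost deserves some caution, since compound 3 rests on a single number and the repeated entries of a closely related compound differ from one another: the several entries of compound 2 in this assay, 7 nM; 20 nM (2 entries)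

The two compounds cannot show whether the step follows from the lost hydrogen-bond donor or from another difference between the nitrogen and oxygen links, and a methylene, sulfur or N-methylamino link would help to separate these readings. Among these compounds, the change is also seen only on the background of compound 3, so whether a step of similar size would apply to compound 1 or compound 2 remains open.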